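A few compounds are considered here, and "the series" means these few. Any claim that something is new, unique, unknown or untested is made for them only; others in the source may bear on it.

Measured so far in an assay on HEK293 cells for displacement of a labelled ligand from 5-hydroxytryptamine receptor 7 (Homo sapiens); on this read-out higher numbers stand for weaker inhibition and lower numbers for stronger inhibition:
compound 1 `CCOc1ccccc1N1CCN(CC(O)CN2C(=O)NC(C)(c3ccc(F)cc3)C2=O)CC1` — 10 nM
compound 2 `CC1(c2ccc(F)cc2)NC(=O)N(CC(O)CN2CCN(c3ccc(F)cc3)CC2)C1=O` — 837 nM

On this read-out compound 2 stands with the highest of the two numbers; its nearest neighbour is compound 1, and the step of an 84-fold higher number from compound 1 to compound 2 (1.92 log units; beyond the scatter) is large and beyond the scatter, so the group on the amine nitrogen in the ring clearly matters here.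

Compound 3 `Cc1ccc(N2CCN(CC(O)CN3C(=O)NC(C)(c4ccc(F)cc4)C3=O)CC2)cc1C` has not been measured. The change from compound 2 is 3,4-dimethylphenyl in place of 4-fluorophenyl on an amine nitrogen in a ring, placed on an amine nitrogen in a ring of a six-membered non-aromatic ring with 2 nitrogen, three ring bonds from the ring nitrogen.

Among the measured compounds shown here, only the step from compound 1 to compound 2 bears on this, and only indirectly: it shows that a change of the aryl group at this position can move the number a long way, but no measured pair compares 3,4-dimethylphenyl with 4-fluorophenyl. The direction is therefore open; a step of moderate size either way, or none beyond the scatter, is plausible.

Compound 3 is expected at 500 nM in this assay, with a range of 100 nM to 2500 nM. This estimate means a step of a 1.7-fold lower number from compound 2 to compound 3 (0.22 log units; within the scatter), expected to stay close to compound 2.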

Compound 3, inhibition constant: 177 nM
Estimate against measurement, compound 3: 2.8-fold (0.45 log units) above; the measured number falls inside the stated range.
By their numbers in this assay, from the lowest: compound 1; then compound 3; then compound 2.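

In this assay, the step of a 4.7-fold lower number from compound 2 to compound 3 (0.67 log units; beyond the scatter) with 3,4-dimethylphenyl in place of 4-fluorophenyl shows that this position still responds when neither aryl group carries an ethoxy group, though less strongly than in the earlier change. The step of an 18-fold higher number from compound 1 to compound 3 (1.25 log units; beyond the scatter) with 3,4-dimethylphenyl in place of 2-ethoxyphenyl shows that this change closes only part of the distance to compound 1, which keeps the lowest number of the three. Nothing available explains the order of these aryl groups.

Still open is whether both methyl groups are needed, since 3-methylphenyl and 4-methylphenyl are absent from the compounds shown. Also open, going by these compounds, is whether the low number of compound 1 would survive with 2-methoxyphenyl or 4-ethoxyphenyl on the same nitrogen.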